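This account rests on a few compounds, and the source may have more. Where it says the series, first, only, none or still open, it means among the compounds named here.

Measured compounds:
compound 1 `N=C(S)CCCCCn1nc(-c2ccccc2)ccc1=O` — 18.2 mg/kg
compound 2 `CC(Cn1nc(-c2ccccc2)ccc1=O)C(=N)S` — 35 mg/kg
compound 3 `C/N=C(\S)C(C)Cn1ncccc1=O` — 68.5 mg/kg

In a functional assay on the whole organism (stomach) for inhibition, with Rattus norvegicus as the target (on this read-out higher numbers stand for an effect only at larger amounts of compound and lower numbers for an effect already at smaller amounts), compound 1 gives 18.2 mg/kg and has the lowest number of the three measured compounds. Compound 2 lies nearest to it, and the step of a 1.9-fold higher number from compound 1 to compound 2 (0.28 log units; within the scatter) is within the scatter, so no order between compound 1 and compound 2 can be read from these numbers. Compound 3 stands furthest away, and its value in this assay lies beyond the scatter from compound 1.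

Compound 4 `C/N=C(/S)CCCCCn1nc(-c2ccccc2)ccc1=O` has not yet been measured in this assay. It differs from compound 1 by a group of 4 heavy atoms (2 carbon, 1 nitrogen, 1 sulfur; no ring) in place of a group of 3 heavy atoms (1 carbon, 1 nitrogen, 1 sulfur; no ring), on a saturated chain carbon, five bonds along the chain from an aromatic nitrogen. Among the compounds with values here, no measured pair shows this change on its own: the step from compound 1 to compound 2 concerns the chain, and compound 3 differs from both measured neighbours in more than one place, so its value does not separate the change in question from the others. With nothing in the data pointing in either direction, the expectation for compound 4 in this assay is a step of a 1.2-fold higher number from compound 1 to compound 4 (0.08 log units; within the scatter) that stays within the scatter. Compound 4 is therefore estimated at 22 mg/kg, with a range from 9 mg/kg to 55 mg/kg.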

Compound 4, dose for half-maximal effect: 45.5 mg/kg
Beside the measured number, compound 4's estimate is 2.1-fold (0.32 log units) below it, and the stated range covers the measured number.
By their numbers in this assay, from the lowest: compounds 1, 2, 4 and 3 (each within the scatter of the next, the first and the last beyond it).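

In this assay, within the data shown here, the group of 4 heavy atoms in place of the group of 3 heavy atoms, on a saturated chain carbon, five bonds along the chain from an aromatic nitrogen, shows as a 2.5-fold higher number from compound 1 to compound 4 (0.40 log units; beyond the scatter) and gives the first direct reading of this change. The earlier pair reached no such result: a 1.9-fold higher number from compound 1 to compound 2 (0.28 log units; within the scatter) concerns the chain and does not separate compound 1 from compound 2, whereas this modest step shows that the change alone can move the number upward, with the core and chain of compound 1 held fixed. The entering group counts 1 hydrogen-bond donor where the leaving group counts 2, but no measurement shown here ties that difference, or any other, to the step.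

The compounds shown leave open whether the same change would give a similar step on the chain of compound 2, since only one matched pair carries it. They also leave open how an ethyl group or a simple amine at this place would compare with compound 1 and compound 4.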